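This account rests on a few compounds, and the source may have more. Where it says the series, first, only, none or still open, it means among the compounds named here.

In a functional assay on MGC-803 cells (Homo sapiens) for inhibition, read by sulforhodamine B assay (a lower number here means a stronger inhibitor, a higher number a weaker inhibitor), compound 1 (`O=C1C=C(NCc2ccccc2)C(=O)c2c1nc1n2[C@H]2OC[C@@H](O)[C@H]2OC1`) gives 2670 nM and compound 2 (`COc1ccc(NC2=CC(=O)c3nc4n(c3C2=O)[C@H]2OC[C@@H](O)[C@H]2OC4)cc1`) gives 1680 nM, so the two values lie within the scatter of each other. Compound 3 (`CCCN(CCC)C1=CC(=O)c2nc3n(c2C1=O)[C@H]1OC[C@@H](O)[C@H]1OC3`) keeps the shared core and carries dipropylamino in place of (4-methoxyphenyl)amino on a double-bonded ring carbon. For the measured compounds named here, only one measured step bears on this change, a 1.6-fold lower number from compound 1 to compound 2 (0.20 log units; within the scatter). That step stays within the scatter, but both of its groups keep a ring and the amine hydrogen, so the data do not cover a group like dipropylamino, which has neither. The expectation is therefore uncertain, and no shift beyond the scatter is predicted. The estimated step in this assay is a 1.5-fold higher number from compound 2 to compound 3 (0.17 log units; within the scatter). For compound 3 the expected value is 2500 nM, with an estimated range from 800 nM to 8000 nM.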

Compound 3, half-maximal inhibitory concentration: > 16000 nM
Compound 3 was reported as a limit (the forecaster's own chance of this, stated with the estimate: 5%); middle value at least 6.4-fold (0.80 log units) away from the limit.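

Compound 3 is reported only as a limit, not as a number: the limit of > 16000 nM in this assay, at which 1 of the 3 values shown sits. In this assay the change from the arylamino group to dipropylamino gives an at least 9.5-fold higher number from compound 2 to compound 3 (0.97 log units; beyond the scatter), and the change from benzylamino gives an at least 5.9-fold higher number from compound 1 to compound 3 (0.77 log units; beyond the scatter), whereas the earlier step between the two ring-bearing groups stayed within the scatter. On this double-bonded ring carbon, then, the amino groups are not interchangeable: the two that keep a ring and the amine hydrogen sit together, and dipropylamino, with no ring and no hydrogen-bond donor, stands apart.

Dipropylamino drops the ring and the amine hydrogen together, and the compounds shown do not separate the two. A propylamino group, which keeps the amine hydrogen without a ring, and a piperidin-1-yl group, which keeps a ring without that hydrogen, would tell them apart.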